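Chain-extended selenocyanate on a methylated anilinopyrimidine core

The source may hold more compounds than are shown below. What is called first, only, known or untested is meant among the compounds shown, and "the series" means these compounds.

Compounds measured so far:
compound 1, `COc1ccc(N(C)c2ccnc(Cl)n2)cc1OCCCBr`, 1280 nM
compound 2, `COc1ccc(N(C)c2ccnc(Cl)n2)cc1OCC[Se]C#N`, 2750 nM

The shared core of compound 1 and compound 2 is fixed, and the two differ only at the end of the chain that hangs from the oxygen on the aromatic ring. In a functional assay on MDA-MB-231 cells (Homo sapiens) for antiproliferative activity, read by MTT assay, with a stated time of 48 h (a lower number here means a stronger inhibitor, a higher number a weaker inhibitor), compound 2 gives 2750 nM, the highest of the two numbers shown; the nearest neighbour is compound 1, which gives 1280 nM in this assay. For the measured compounds named here, the one measured step, a 2.1-fold higher number from compound 1 to compound 2 (0.33 log units; beyond the scatter), is a modest one and concerns an exchange at the chain end, not a change of chain length.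

Compound 3, `COc1ccc(N(C)c2ccnc(Cl)n2)cc1OCCCCC[Se]C#N`, keeps the selenocyanate end of compound 2 and lengthens the chain: a group of 6 heavy atoms (4 carbon, 1 nitrogen, 1 selenium; no ring) in place of a group of 3 heavy atoms (1 carbon, 1 nitrogen, 1 selenium; no ring), on a saturated chain carbon, two bonds along the chain from an oxygen on an aromatic ring. Going by the values given here, no measured step follows a change of this kind, so the step to compound 3 in this assay can only be expected to be small or none beyond the scatter, with the size of a 2.1-fold higher number from compound 1 to compound 2 (0.33 log units; beyond the scatter) as the only guide to how far a chain-end change has moved the number here.

Compound 3 is therefore expected to give about 2500 nM in this assay, within 1000 nM to 6500 nM, a step of a 1.1-fold lower number from compound 2 to compound 3 (0.04 log units; within the scatter) that is expected to stay near compound 2.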

Compound 3, half-maximal inhibitory concentration: > 10000 nM
Compound 3 ended at the assay's limit; the forecaster's own chance of this, stated with the estimate: 5%; middle value at least 4.0-fold (0.60 log units) away from the limit.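

In this assay compound 3 gives > 10000 nM, which is a limit of the assay and not a number. With the selenocyanate end kept, lengthening the chain gives an at least 3.6-fold higher number from compound 2 to compound 3 (0.56 log units; beyond the scatter), so at this place, on a saturated chain carbon, two bonds along the chain from an oxygen on an aromatic ring, chain length alone moves the number beyond the scatter, which the exchange at the chain end between compound 1 and compound 2 could not show. Set against the bromine-ended chain, the change gives an at least 7.8-fold higher number from compound 1 to compound 3 (0.89 log units; beyond the scatter), which leaves compound 3 as the weakest of the three, although its true size is hidden and only a bound can be given: the limit of > 10000 nM in this assay, at which 1 of the 3 values shown sits.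

The compounds shown leave open how far past the limit compound 3 lies, and whether the number rises steadily with chain length or turns sharply somewhere between the chain of compound 2 and that of compound 3. They also leave open whether the long chain would behave the same way with an amine, a carboxylic acid or a thiocyanate at its end in place of the selenocyanate.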